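Methyl-to-hydrogen steps on the aromatic nitrogen chain

A few compounds are considered here, and "the series" means these few. Any claim that something is new, unique, unknown or untested is made for them only; others in the source may bear on it.

Measured compounds in a functional assay on MCF7 cells (Homo sapiens) for cytotoxicity, read by MTT assay, with a stated time of 48 h; on this read-out lower numbers stand for stronger inhibition and higher numbers for weaker inhibition:
compound 1 `CCn1c(/C=C2/C(=O)Nc3ccc(F)cc32)nc2ccccc21`: > 50000 nM
compound 2 `CC(C)n1c(/C=C2/C(=O)Nc3ccc(F)cc32)nc2ccccc21`: 29000 nM
compound 3 `CCn1c(/C=C2/C(=O)Nc3ccc(Br)cc32)nc2ccccc21`: "not determined" (no result reported)

Compound 2 gives 29000 nM in this assay. For compound 1 the result is a limit of the assay, > 50000 nM (the limit of > 50000 nM in this assay, at which 1 of the 3 values shown sits). The change between them, (hydrogen in place of methyl on a saturated chain carbon bound to an aromatic nitrogen and a saturated chain carbon), gives an at least 1.7-fold higher number from compound 2 to compound 1 (0.23 log units; that floor lies within the scatter). The difference between the cores of compound 2 and compound 3 is not broken down here. Compound 4 `Cn1c(/C=C2/C(=O)Nc3ccc(Br)cc32)nc2ccccc21` is unmeasured; it differs from compound 3 by hydrogen in place of methyl on a saturated chain carbon bound to an aromatic nitrogen. This is the same kind of change as from compound 2 to compound 1, though the place differs: there the carbon was bound to an aromatic nitrogen and a saturated chain carbon, here to an aromatic nitrogen only. With compound 3 undetermined, the expectation for compound 4 rests on compound 1 and compound 2 both sitting near or at the limit; compound 4 is expected at 60000 nM, between 15000 nM and 200000 nM, likely again only as a limit.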

Compound 4, half-maximal inhibitory concentration: > 50000 nM
Compound 4 gave a limit, no number (the forecaster's own chance of this, stated with the estimate: 60%); the middle value does not contradict the limit.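

Among the compounds shown here, compound 3 has no reported result, so no step to compound 4 can be read. Compound 4 gives > 50000 nM, a limit and not a number. The compounds shown leave open whether hydrogen in place of methyl at this place changes the result.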